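The source may hold more compounds than are shown below. What is called first, only, known or untested is meant among the compounds shown, and "the series" means these compounds.

Compound 1, with the structure `COc1ccc2ncc(S(=O)(=O)c3ccc(C)c(Cl)c3)c(N3CCC(C)CC3)c2c1`, gives 85% in an assay on isolated protein for displacement of a labelled ligand from metabotropic glutamate receptor 5 (Homo sapiens), with a stated time of 60 min, tested at 1 uM; on this read-out higher numbers stand for more inhibition at the one concentration tested (going by the name of the read-out) and lower numbers for less inhibition. Compound 2, with the structure `CC1CCN(c2c(S(=O)(=O)c3ccc(Cl)cc3)cnc3c(F)cccc23)CC1`, gives 85% in this assay, and compound 3, with the structure `Cc1ccc2ncc(S(=O)(=O)c3ccc(C)c(Cl)c3)c(N3CCC(C)CC3)c2c1`, gives 91%. On these three numbers compound 1 is level with compound 2 at the digits reported, and the two together are the lowest of the set; the nearest neighbour of compound 1 is compound 2, with no change at the digits reported, and the furthest is compound 3, reached by methyl in place of methoxy on an aromatic carbon, a step of a number 6 percentage points higher from compound 1 to compound 3 (within the scatter), which lies within the scatter.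

Compound 4, with the structure `COc1ccc2ncc(S(=O)(=O)c3ccc(OC)c(Cl)c3)c(N3CCC(C)CC3)c2c1`, differs from compound 1 by methoxy in place of methyl on an aromatic carbon. Within the data shown here, only one measured step speaks to this kind of exchange, the one from compound 1 to compound 3, which swaps methoxy and methyl in the other direction and on a different ring and stays within the scatter. Nothing in the data therefore points to a step beyond the scatter in this assay, in either direction. Compound 4 is accordingly expected to show a number 1 percentage points lower from compound 1 to compound 4 (within the scatter), which would place it at an estimated 84%, with a range from 70% to 94%.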

Compound 4, a percentage reported as inhibition, at one concentration (the size of the read-out at that concentration, not a potency): 21%
Compound 4: middle estimate off by 63 percentage points, on the high side, outside the stated range (below it).
By their numbers in this assay, from the lowest: compound 4; then compounds 1, 2 and 3 (each within the scatter of the next).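

On the 3-chloro-4-methylphenyl group of compound 1, the change to 3-chloro-4-methoxyphenyl gives a number 64 percentage points lower from compound 1 to compound 4 (beyond the scatter) in this assay, so this place on the ring of carbon only, ortho to a chloro group and para to a large group, does not treat methoxy and methyl alike. The earlier compounds had shown an exchange of these two groups only on the other ring, in the opposite direction, as a number 6 percentage points higher from compound 1 to compound 3 (within the scatter), so that step gave no sign of what happens at this position, and within these compounds the outcome of the exchange differs with its place. Nothing available here accounts for the drop, whether the added oxygen or the extra heavy atom is what matters.

The compounds shown leave open whether an ethyl, a hydroxyl or a plain hydrogen at this place would follow methyl or methoxy, and whether an ethoxy would go further in the same direction. They also leave open whether the same exchange has a like effect when the core carries the methyl of compound 3 rather than the methoxy of compound 1, and how the drop at the one concentration tested would translate into a potency.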